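The compounds below may be only part of what the source reports. "The series", "measured", "known", "first", "only" and "open" are said of these compounds alone.

Compound 3 `Cc1ccc(-c2ccc(N(C[C@@H](N)CC(C)C)C(=O)[C@@H]3C[C@H]3c3ccccc3)cc2)cc1` stands with the highest number of the three compounds measured in a functional assay for agonist activity at G protein-coupled receptor 88 (Homo sapiens), read by HTRF and cAMP accumulation; a higher number here means that more compound is needed for the effect, a lower number that less compound is needed; compound 3 gives 360 nM, while compound 1 `CC[C@H](C)[C@@H](CN(C(=O)[C@@H]1C[C@H]1c1ccccc1)c1ccc(-c2ccccc2)cc1)NC(C)=O` gives 5.8 nM and compound 2 `CO[C@H](C)[C@H](N)CN(C(=O)[C@@H]1C[C@H]1c1ccccc1)c1ccc(-c2ccccc2)cc1` gives 0.68 nM. Going by the values given here, the one measured step between compounds differing in a single place, an 8.5-fold lower number from compound 1 to compound 2 (0.93 log units; beyond the scatter), changes the saturated chain carbon bound to the amide-type nitrogen, not the aromatic ring. Compound 4 `CC(C)C[C@H](N)CN(C(=O)[C@@H]1C[C@H]1c1ccccc1)c1ccc(-c2ccc(Cl)cc2)cc1` differs from compound 3 by chloro in place of methyl on an aromatic carbon. No measured step touches this aromatic carbon, so nothing shown here points to a shift beyond the scatter in either direction, and the expected step of a 1.2-fold lower number from compound 3 to compound 4 (0.08 log units; within the scatter) is small. Compound 4 is therefore estimated to give 300 nM in this assay, with a range from 100 nM to 1000 nM.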

Compound 4, half-maximal effective concentration: 640 nM
Compound 4: the middle estimate sits 2.1-fold (0.33 log units) below what was measured, and the stated range covers the measured number.
By their numbers in this assay, from the lowest: compound 2; then compound 1; then compounds 3 and 4 (each within the scatter of the next).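

Methyl and chloro on this aromatic carbon, para to a large group, give a 1.8-fold higher number from compound 3 to compound 4 (0.25 log units; within the scatter) in this assay and so cannot be told apart, which is the first reading at this position that the earlier compounds could not give. No measured evidence bears on this result. On these data alone, whether a carboxylic acid, an amine or a methoxy group at this position would move the number beyond the scatter stays open, as does whether methyl and chloro would also read alike with the chain of compound 2, which carries neither group.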